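This account rests on a few compounds, and the source may have more. Where it says the series, first, only, none or still open, it means among the compounds named here.

Measured in a functional assay on CCRF-CEM cells (Homo sapiens) for cytotoxicity; a higher number here means a weaker inhibitor, a lower number a stronger inhibitor:

- Compound 1 `Nc1nc(=O)n([C@H]2C=C(F)[C@@H](CO)O2)cc1F`: > 100000 nM, a limit
- Compound 2 `Nc1ncnc2c1ncn2[C@H]1C=C(F)[C@@H](CO)O1`: > 100000 nM, a limit
- Compound 3 `OC[C@H]1O[C@@H](n2cnc3c(O)ncnc32)C=C1F`: 77700 nM

Compound 2 has no exact number, only the limit > 100000 nM. Compound 1 and compound 2 both stand at the limit of > 100000 nM in this assay, at which 2 of the 3 values shown sit. Next in this assay is compound 4 `Nc1ncnc2c1ncn2[C@@H]1C=C(F)[C@H](CO)O1`, and the change from compound 2 is as follows: the two compounds have the same atoms and bonds and differ only in configuration as drawn: 2 of 2 stereo elements differ (all stereocentres are inverted: mirror images); a stereocentre at a saturated ring carbon is drawn R in compound 2 and S in compound 4; a stereocentre at a saturated ring carbon is drawn R in compound 2 and S in compound 4.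

Within the data shown here, no measured step inverts a stereocentre, so none bears directly on this change. Among the measured compounds shown here, the only measured step is an at least 1.2-fold lower number from compound 2 to compound 3 (0.10 log units; that floor lies within the scatter), and it exchanges a group without touching the configuration. It gives no ground for expecting a move in either direction beyond the scatter, and compound 4 may well report only a limit too. The expected step is a number no higher from compound 2 to compound 4 (the limit leaves the size open), with no direction favoured. The estimate for compound 4 is 100000 nM, with an expected range of 40000 nM to 150000 nM.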

Compound 4, half-maximal inhibitory concentration: > 100000 nM
Compound 4: a limit, no number; the forecaster's own chance of this, stated with the estimate: 75%; the middle value lies on the limit itself.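

In this assay compound 4 gives > 100000 nM, a limit. Among these compounds, compound 2 also stands at a limit, and no step between these two mirror images can be read. The compounds shown leave open whether inverting both stereocentres changes the read-out at all.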